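Methoxy added to the aryl ring of a nitrofuran amide

This account rests on a few compounds, and the source may have more. Where it says the series, first, only, none or still open, it means among the compounds named here.

Measured compounds:
compound 1, `COc1cccc(-c2csc(NC(=O)c3ccc([N+](=O)[O-])cc3)n2)c1`, in an ADME assay on Vero cells (Chlorocebus sabaeus) for cytotoxicity, read by MTT assay, with a stated time of 72 h; a higher number here means a weaker inhibitor, a lower number a stronger inhibitor: > 90000 nM
compound 2, `O=C(Nc1nc(-c2ccccc2)cs1)c1ccc([N+](=O)[O-])o1`, in this assay: 41700 nM

The value of compound 1 is a limit of the assay and not a number. Going by the values given here, compound 2 therefore holds the only number in this assay, with the other value sitting at the limit of > 90000 nM in this assay, at which 1 of the 2 values shown sits. Compound 3, `COc1ccccc1-c1csc(NC(=O)c2ccc([N+](=O)[O-])o2)n1`, differs from compound 2 by methoxy in place of hydrogen on an aromatic carbon. With no measured step of this kind in the series, no shift beyond the usual scatter is expected, and compound 3 is estimated at 50000 nM (range 20000 nM to 120000 nM), an expected step of a 1.2-fold higher number from compound 2 to compound 3 (0.08 log units; within the scatter).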

Compound 3, half-maximal inhibitory concentration: 42000 nM
Compound 3: middle estimate off by 1.2-fold (0.08 log units), on the high side; measured number inside the range.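

In this assay, going by these compounds alone, the change from phenyl to 2-methoxyphenyl gives a 1.0-fold higher number from compound 2 to compound 3 (0.00 log units; within the scatter), the first readable step. Methoxy on this aromatic carbon, ortho to a large group, therefore leaves the number within the scatter of the unsubstituted compound. Nothing at hand bears on why this step is so small.

On these data alone, whether the same holds for other groups at this position, such as an amine or a carboxylic acid, stays open. So does the outcome for methoxy at other carbons of the six-membered ring.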